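Swapping the ethoxyphenyl of compound 3 for a bromophenyl

A few compounds are considered here, and "the series" means these few. Any claim that something is new, unique, unknown or untested is made for them only; others in the source may bear on it.

Measured in a functional assay on HGC-27 cells (Homo sapiens) for cytotoxicity, read by MTT assay, with a stated time of 72 h; on this read-out lower numbers stand for stronger inhibition and higher numbers for weaker inhibition:
Compound 1, `CCCCCCCCNc1nc(SCc2ccc(C(F)(F)F)cc2)nc2ccccc12`, gives 13400 nM.
Compound 2, `FC(F)(F)c1ccc(CSc2nc(Nc3ccccc3)c3ccccc3n2)cc1`, gives 26400 nM.
Compound 3, `CCOc1ccccc1Nc1nc(SCc2ccc(C(F)(F)F)cc2)nc2ccccc12`, gives only a limit, > 50000 nM.

Among the measured compounds shown here, compound 3 is the one whose value is a limit of this assay and not a number (the limit of > 50000 nM in this assay, at which 1 of the 3 values shown sits). Compound 4, `FC(F)(F)c1ccc(CSc2nc(Nc3cccc(Br)c3)c3ccccc3n2)cc1`, differs from it in one place: 3-bromophenyl in place of 2-ethoxyphenyl on a nitrogen on an aromatic ring. For the measured compounds named here, three measured steps bear on this change. Removing the ethoxy from the phenyl ring goes the other way, an at least 1.8-fold higher number from compound 2 to compound 3 (0.27 log units; that floor lies within the scatter), so the ethoxy is what carries compound 3 past the limit. The other two, an at least 3.7-fold higher number from compound 1 to compound 3 (0.57 log units; beyond the scatter) and a 2.0-fold higher number from compound 1 to compound 2 (0.29 log units; within the scatter), put the plain phenyl of compound 2 closer to compound 1 than the ethoxyphenyl is. Compound 4 carries a phenyl with bromine rather than ethoxy, so its value is expected to fall back from the limit toward that of compound 2, a step of an at least 1.6-fold lower number from compound 3 to compound 4 (0.22 log units; that floor lies within the scatter). The estimate for compound 4 in this assay is 30000 nM, within a range from 12000 nM to 70000 nM.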

Compound 4, half-maximal inhibitory concentration: 18300 nM
Compound 4: the middle estimate sits 1.6-fold (0.21 log units) above what was measured; the range from low to high includes it.
By their numbers in this assay, from the lowest: compounds 1, 4 and 2 (each within the scatter of the next). At a limit, above all of these: compound 3.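

In this assay the 3-bromophenyl clearly comes back from the limit, with an at least 2.7-fold lower number from compound 3 to compound 4 (0.43 log units; beyond the scatter). Compound 3 holds a limit and not a number, so the full size of that step stays unknown: the limit of > 50000 nM in this assay, at which 1 of the 4 values shown sits.

The bromo itself gives no difference that can be told from the scatter, with a 1.4-fold lower number from compound 2 to compound 4 (0.16 log units; within the scatter), and the same holds for the exchange of octyl for 3-bromophenyl, with a 1.4-fold higher number from compound 1 to compound 4 (0.14 log units; within the scatter), so among these four compounds only the 2-ethoxyphenyl stands apart on this nitrogen.

The 2-ethoxyphenyl and 3-bromophenyl differ both in the group they carry and in where it sits on the phenyl ring, so these compounds cannot separate those two changes. On these data alone, how an amine or a carboxylic acid on that ring would read in this assay also stays open.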